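Halogen for isopropyl on the second aryl ring

The compounds below may be only part of what the source reports. "The series", "measured", "known", "first", "only" and "open" are said of these compounds alone.

Compound 1 `CC(C)c1ccc(-c2nc(SCc3cn(CC(=O)NC(=O)Nc4ccccn4)nn3)nc(Nc3ccc(Cl)cc3)c2C#N)cc1`: 860 nM
Compound 2 `CC(C)c1ccc(Nc2nc(SCc3cn(CC(=O)NC(=O)Nc4ccccn4)nn3)nc(-c3ccc(C(C)C)cc3)c2C#N)cc1`: 4380 nM

In a functional assay on B16-F10 cells (Mus musculus) for inhibition, read by MTT assay, with a stated time of 72 h (a lower number here means a stronger inhibitor, a higher number a weaker inhibitor), compound 2 gives the highest of the two numbers, and its nearest neighbour is compound 1 at 860 nM. Within the data shown here, compound 3 `CC(C)c1ccc(Nc2nc(SCc3cn(CC(=O)NC(=O)Nc4ccccn4)nn3)nc(-c3ccc(Br)cc3)c2C#N)cc1` differs from compound 2 by bromo in place of isopropyl on an aromatic carbon, a change on the other six-membered aromatic ring of carbon only than the one altered in the step of a 5.1-fold higher number from compound 1 to compound 2 (0.71 log units; beyond the scatter). Among the measured compounds shown here, no measured step bears on this ring directly; the step from compound 1 to compound 2 only suggests that a halogen in place of isopropyl lowers the number. Compound 3 is therefore expected to give a modest lowering, a 2.4-fold lower number from compound 2 to compound 3 (0.39 log units; beyond the scatter), with an estimate of 1800 nM in a range from 600 nM to 5500 nM.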

Compound 3, half-maximal inhibitory concentration: 42 nM
Compound 3: middle estimate off by 43-fold (1.63 log units), on the high side; the whole stated range lies above it.
By their numbers in this assay, from the lowest: compound 3; then compound 1; then compound 2.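

The change from 4-isopropylphenyl to 4-bromophenyl on this ring is the largest step in the series in this assay, a 100-fold lower number from compound 2 to compound 3 (2.02 log units; beyond the scatter), against a 5.1-fold higher number from compound 1 to compound 2 (0.71 log units; beyond the scatter) on the other ring. The number at this position is thus highly sensitive to the group on this aromatic carbon, with bromo, a single heavy atom, giving by far the lower number. No measurement shown accounts for the size of this step.

Open, on these data alone, is whether this result is specific to bromo or would extend to fluoro, methoxy or an amine at the same place. Also open, as far as these compounds go, is whether bromo gives a step of this size when the other ring carries chloro.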